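Cyano in Place of Formyl on a Sulfonyl-Bound Phenyl

The source may hold more compounds than are shown below. What is called first, only, known or untested is meant among the compounds shown, and "the series" means these compounds.

In a functional assay on SUP-B15 cells (Homo sapiens) for antiproliferative activity, with a stated time of 72 h (on this read-out higher numbers stand for an effect only at larger amounts of compound and lower numbers for an effect already at smaller amounts), three compounds have been measured. Compound 1 `COc1ccc(-c2c(I)c(=O)c3c(OC)cc(OC)cc3n2S(=O)(=O)c2ccc(OC)cc2)cc1` gives 12300 nM, and compound 2 `COC(=O)c1cc(=O)c2c(OC)cc(OC)cc2[nH]1` gives 16100 nM. Compound 3 `COc1ccc(-c2cc(=O)c3c(OC)cc(OC)cc3n2S(=O)(=O)c2ccc(C=O)cc2)cc1` gives only a limit of the assay, > 34400 nM, and not a number. Compound 3 thus stands at the limit of > 34400 nM in this assay, at which 1 of the 3 values shown sits. Compound 4 `COc1ccc(-c2cc(=O)c3c(OC)cc(OC)cc3n2S(=O)(=O)c2ccc(C#N)cc2)cc1` differs from compound 3 in one place: cyano in place of formyl on an aromatic carbon. Going by the values given here, no measured pair shows this change, so the size of the step is not known from the data. Compound 4 is expected to stay close to compound 3, with a step that the limit leaves unreadable from compound 3 to compound 4 that would not go beyond the usual scatter. The expected value for compound 4 is therefore 40000 nM, within 15000 nM to 110000 nM.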

Compound 4, half-maximal effective concentration: 7900 nM
Estimate against measurement, compound 4: 5.1-fold (0.70 log units) above; measured number outside the range, below it.
By their numbers in this assay, from the lowest: compounds 4, 1 and 2 (each within the scatter of the next, the first and the last beyond it). At a limit, above all of these: compound 3.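

In this assay the change from formyl to cyano gives an at least 4.3-fold lower number from compound 3 to compound 4 (0.63 log units; beyond the scatter) on this aromatic carbon of the sulfonyl-bound phenyl. This position therefore responds to the group it carries. The two groups match in heavy atoms and hydrogen-bond acceptors, so those counts alone do not separate them in this read-out.

On these data alone, whether an amine, a carboxylic acid or a longer chain here would move the number further remains open. The full size of the step also stays unknown, because compound 3 gives only a limit of the assay: the limit of > 34400 nM in this assay, at which 1 of the 4 values shown sits.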